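The compounds below may be only part of what the source reports. "The series", "measured", "known", "first", "only" and "open" are said of these compounds alone.

In a functional assay on RKO cells (Homo sapiens) for cytotoxicity, read by resazurin assay, with a stated time of 72 h (a lower number here means a stronger inhibitor, a higher number a weaker inhibitor), compound 1 (`c1ccc(Nc2nc(-n3cnc4ccccc43)cs2)cc1`) gives > 100000 nM, which is a limit of the assay and not a number. Compound 2 (`Cc1cn(-c2csc(Nc3cccc(Br)c3)n2)c(C)n1`) gives > 100000 nM, also a limit. Compound 3 (`COc1ccc(Nc2nc(-n3cnc4ccccc43)cs2)cc1`) gives > 100000 nM, again a limit. Within the data shown here, compound 1 therefore stands with the other two, and the whole series so far rests on (the limit of > 100000 nM in this assay, at which 3 of the 3 values shown sit).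

Compound 4 (`Cc1nc2ccccc2n1-c1csc(Nc2ccccc2)n1`) departs from compound 1 by one change: methyl in place of hydrogen on an aromatic carbon. Methyl takes the place of hydrogen on an aromatic carbon, between two ring nitrogen atoms. Among the measured compounds shown here, the only measured step that bears on this is a step that the two limits leave unreadable from compound 1 to compound 3, in which methoxy replaces hydrogen on an aromatic carbon, and it offers no size to carry over. With compound 1 recorded at > 100000 nM, no step beyond the scatter is expected in either direction, and the estimated step is a number no higher from compound 1 to compound 4 (the limit leaves the size open). Compound 4 is expected at about 100000 nM, with an estimated range from 40000 nM to 200000 nM.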

Compound 4, half-maximal inhibitory concentration: 40000 nM
Compound 4: middle estimate off by 2.5-fold (0.40 log units), on the high side; measured number inside the range.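

With compound 4, the series gains its first value in this assay that is a number and not a limit. Methyl in place of hydrogen on the aromatic carbon between two ring nitrogen atoms, next to the ring atom that bears a large group, gives an at least 2.5-fold lower number from compound 1 to compound 4 (0.39 log units; beyond the scatter), so this position can move the read-out, where the earlier comparison gave no readable size. Compound 4 alone has left the limit, which sets the background for this single reading: the limit of > 100000 nM in this assay, at which 3 of the 4 values shown sit.

Going by these compounds, how far the number would move with ethyl, an amine or a chlorine atom at this same carbon remains open. Also open, on these data alone, is whether the methyl would give a step of similar size on the core of compound 3, which carries a methoxy group.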